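Benzodioxinylmethyl amine tail in the bis(trifluoromethyl)sulfonamide series

A few compounds are considered here, and "the series" means these few. Any claim that something is new, unique, unknown or untested is made for them only; others in the source may bear on it.

Measured so far in a functional assay on BE(2)-C cells (Homo sapiens) for inhibition, read by MTT assay, with a stated time of 72 h; a higher number here means a weaker inhibitor of growth, a lower number a stronger inhibitor of growth:
compound 1, `O=S(=O)(NCCNCc1ccc(-c2ccccc2)cc1)c1cc(C(F)(F)F)cc(C(F)(F)F)c1`: 2700 nM
compound 2, `O=S(=O)(NCCCCNCc1ccc(Br)cc1)c1cc(C(F)(F)F)cc(C(F)(F)F)c1`: 2200 nM
compound 3, `O=S(=O)(NCCCNCc1ccc(Cl)c(Cl)c1)c1cc(C(F)(F)F)cc(C(F)(F)F)c1`: 2900 nM

The three numbers lie within the scatter of one another. Compound 3 gives 2900 nM, and its gap to compound 1 and to compound 2 is in each case within the scatter. Among the measured compounds shown here, the one counted step, a 1.3-fold higher number from compound 2 to compound 3 (0.12 log units; within the scatter), combines a change of the halogenated aryl group with a change of chain length and still stays within the scatter; compound 1, with a biphenyl group on a shorter chain, shows the same picture. Nothing in this set separates one aryl tail from another.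

Compound 4, `O=S(=O)(NCCCNCC1COc2ccccc2O1)c1cc(C(F)(F)F)cc(C(F)(F)F)c1`, differs from compound 3 by 2,3-dihydro-1,4-benzodioxin-2-yl in place of 3,4-dichlorophenyl on a saturated chain carbon bound to an amine nitrogen. For the measured compounds named here, no measured step covers an exchange of a halogenated aromatic ring for a saturated ring fused to an aromatic one, so the step in this assay is uncertain. Going by the values given here, since aryl variation so far left the number within the scatter, no step beyond the scatter is expected, with slight allowance for a weaker result: a 1.2-fold higher number from compound 3 to compound 4 (0.08 log units; within the scatter). Compound 4 is estimated at 3500 nM, range 1500 nM to 8000 nM.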

Compound 4, concentration for 50% growth inhibition: 2800 nM
Compound 4: the middle estimate sits 1.3-fold (0.10 log units) above what was measured, within the range that was stated.
By their numbers in this assay, from the lowest: compounds 2, 1, 4 and 3 (each within the scatter of the next).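

In this assay, 2,3-dihydro-1,4-benzodioxin-2-yl in place of 3,4-dichlorophenyl on a saturated chain carbon bound to an amine nitrogen gives a 1.0-fold lower number from compound 3 to compound 4 (0.02 log units; within the scatter). The earlier compounds shown here varied only aromatic carbon rings with halogen or phenyl substituents, whereas this change removes both chlorine atoms and brings in a six-membered non-aromatic ring with 2 hetero atoms, and the number still does not move beyond the scatter. This position therefore accepts a tail of a different kind without a readable change in growth inhibition, and no supporting data bear on why.

The compounds shown leave open whether a cyclohexylmethyl or pyridinylmethyl group at this amine nitrogen would move the number beyond the scatter. Also open, as far as these compounds go, is what an amide in place of the amine would do with the same tail.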